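The source may hold more compounds than are shown below. What is called first, only, known or untested is meant among the compounds shown, and "the series" means these compounds.

In a functional assay on PC-3 cells (Homo sapiens) for inhibition, read by sulforhodamine B assay, with a stated time of 72 h (on this read-out lower numbers stand for stronger inhibition and higher numbers for weaker inhibition), compound 2 `Nc1sc(-c2ccc(Cl)cc2)c(-c2ccc(Cl)cc2)c1C(=O)Nc1ccccc1` gives > 50000 nM, a limit of the assay and not a number. Compound 1 `CC1CCN(C(=O)c2c(N)sc(-c3ccc(Cl)cc3)c2-c2ccc(Cl)cc2)CC1` gives 5750 nM. Compound 3 `Nc1sc(-c2ccc(Cl)cc2)c(-c2ccc(Cl)cc2)c1C(=O)NC1CCC(O)CC1` differs from compound 2 by 4-hydroxycyclohexyl in place of phenyl on an amide-type nitrogen, with 4-hydroxycyclohexyl in place of phenyl on an amide-type nitrogen. Among the measured compounds shown here, the only measured step bearing on this is an at least 8.6-fold higher number from compound 1 to compound 2 (0.93 log units; beyond the scatter), where anilino replaced 4-methylpiperidin-1-yl, and it lies beyond the scatter. Losing the phenyl is therefore expected to give a lower number in this assay, by a step of similar or smaller size. The expected step is an at least 3.3-fold lower number from compound 2 to compound 3 (0.52 log units; beyond the scatter) in this direction. Compound 3 is estimated at 15000 nM, with an expected range of 5000 nM to 50000 nM.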

Compound 3, half-maximal inhibitory concentration: 5670 nM
For compound 3 the middle estimate is 2.6-fold (0.42 log units) above the measured one; the range from low to high includes it.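

Replacing phenyl with 4-hydroxycyclohexyl on the amide-type nitrogen in this assay gives an at least 8.8-fold lower number from compound 2 to compound 3 (0.94 log units; beyond the scatter), so an aromatic ring is not required on this nitrogen. Compound 2 stands at a limit of the assay and not a number: the limit of > 50000 nM in this assay, at which 1 of the 3 values shown sits. The (4-hydroxycyclohexyl)amino group in place of 4-methylpiperidin-1-yl on the carbonyl carbon gives a 1.0-fold lower number from compound 1 to compound 3 (0.01 log units; within the scatter), so these two groups are not told apart here, and only anilino stands apart.

On these data alone, it remains open whether the ring or its hydroxyl carries the gain. Plain cyclohexyl, or 4-aminocyclohexyl, on this nitrogen would separate the two.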